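Urea-linked oxadiazoles: a 4-iodophenyl swap on the aryl

A few compounds are considered here, and "the series" means these few. Any claim that something is new, unique, unknown or untested is made for them only; others in the source may bear on it.

Measured so far:
- compound 1, `O=C(Nc1ccc(I)cc1)N1CCC[C@H]1c1nc(-c2ccccc2)no1`, gives > 50000 nM in an ADME assay on MCF-10A cells (Homo sapiens) for inhibition, with a stated time of 48 h (on this read-out lower numbers stand for stronger inhibition and higher numbers for weaker inhibition), a limit of the assay rather than a number.
- compound 2, `Cc1cccc(-c2noc([C@@H]3CCCN3C(=O)Nc3ccc(Cl)cc3)n2)c1`, gives > 50000 nM in this assay, again a limit and not a number.

Within the data shown here, compound 2 therefore stands at the limit of the assay, and the one other value shown sits at the same limit: the limit of > 50000 nM in this assay, at which 2 of the 2 values shown sit. Among the measured compounds shown here, no step between measured compounds can be drawn, since neither value is a number.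

The next compound, compound 3, is `O=C(Nc1ccc(Cl)cc1)N1CCC[C@H]1c1nc(-c2ccc(I)cc2)no1`. Its change from compound 2 is 4-iodophenyl in place of 3-methylphenyl on an aromatic carbon. Compound 1 already carries a 4-iodophenyl, on the urea side, and sits at the limit in this assay, so the two measured compounds give no sign of any movement that the change could be tied to.

The expected step in this assay is none beyond the scatter: a step that the limit leaves unreadable from compound 2 to compound 3 is the estimated shift, with the most likely outcome another limit. Compound 3 is expected at 60000 nM in this assay, within 20000 nM to 300000 nM.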

Compound 3, half-maximal inhibitory concentration: > 50000 nM
Compound 3: a limit, no number; the forecaster's own chance of this, stated with the estimate: 80%; the middle value does not contradict the limit.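

No step can be read from compound 2 to compound 3, since both values are limits of the assay and not numbers: the limit of > 50000 nM in this assay, at which 3 of the 3 values shown sit. The compounds shown leave open whether any change on the shared core gives a number in this assay and how large the step for 4-iodophenyl in place of 3-methylphenyl really is.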